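The source may hold more compounds than are shown below. What is called first, only, known or untested is meant among the compounds shown, and "the series" means these compounds.

Compound 1 `CCCCCn1c(N)nc2c(OC)cccc21` gives 3740 nM in an assay on HEK293 cells for agonist activity at Toll-like receptor 8 (Homo sapiens), read by reporter gene assay; on this read-out lower numbers stand for an effect already at smaller amounts and higher numbers for an effect only at larger amounts of compound; compound 3 `CCCCCn1c(N)nc2c(CC)cccc21` gives 1650 nM; compound 2 `CCCCCn1c(N)nc2c(C(F)(F)F)cccc21` is reported as "not active" (no number reported), with no number.

Going by the values given here, compound 3 therefore stands with the lowest of the two numbers, the nearest being compound 1, and the only step that shows a single change, a 2.3-fold lower number from compound 1 to compound 3 (0.36 log units; beyond the scatter), is modest. Compound 4 `CCCCCn1c(N)nc2c(N)cccc21` carries amino in place of ethyl on an aromatic carbon. Among the compounds with values here, no measured step tests an amino group here, and compound 2 shows that a change at this position can remove activity altogether. The step is therefore expected to be small and uncertain, in the direction of a higher number, roughly a 1.8-fold higher number from compound 3 to compound 4 (0.26 log units; within the scatter). Compound 4 is expected to give about 3000 nM, in a range from 1000 nM to 15000 nM.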

Compound 4, half-maximal effective concentration: 6600 nM
The estimate for compound 4 lay 2.2-fold (0.34 log units) below the measured number; low and high end bracket the measured number.
By their numbers in this assay, from the lowest: compound 3; then compounds 1 and 4 (each within the scatter of the next).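

In this assay, amino in place of ethyl on this aromatic carbon gives a 4.0-fold higher number from compound 3 to compound 4 (0.60 log units; beyond the scatter) and so leaves ethyl with the lowest number of the three measured groups. Amino in place of methoxy gives a 1.8-fold higher number from compound 1 to compound 4 (0.25 log units; within the scatter) and so does not separate these two groups. Amino, with a hydrogen-bond donor that ethyl lacks, still gives a measurable number here, unlike trifluoromethyl in compound 2. No measurement shown explains these differences. As far as these compounds go, whether a propyl chain or a chlorine atom here would bring the number below that of compound 3 remains open.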